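Methylsulfanyl to aminoamino on two related cores

The source may report more compounds than this note shows. Statements on the series, on what has been measured and on what is new or still open speak of the compounds shown alone.

Measured compounds in a functional assay on microsomes for inhibition, with a stated time of 1 h; on this read-out higher numbers stand for weaker inhibition and lower numbers for stronger inhibition:
compound 1 `COc1ccc(-c2nc(SC)n(C)c(=O)c2C#N)cc1` gives 53 ug/mL
compound 2 `COc1ccc(-c2nc(NN)n(C)c(=O)c2C#N)cc1` gives 39 ug/mL
compound 3 `CSc1nc(-c2ccccc2O)c(C#N)c(=O)n1C` gives 44 ug/mL

Compound 1 and compound 2 share a core and differ only where aminoamino in place of methylsulfanyl on an aromatic carbon is made. The step in this assay is a 1.4-fold lower number from compound 1 to compound 2 (0.13 log units; within the scatter), so the two numbers sit within the usual scatter of each other and no direction can be read from this pair.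

Compound 3 carries a different core; the difference between the core of compound 1 and the core of compound 3 is not broken down here. Compound 3 and compound 2 give numbers within the scatter of each other, and the same holds for compound 3 against compound 1.

Compound 4 `Cn1c(NN)nc(-c2ccccc2O)c(C#N)c1=O` is not yet measured. It stands to compound 3 as compound 2 stands to compound 1: aminoamino in place of methylsulfanyl on an aromatic carbon. The surroundings are not the same word for word, since here the group is meta to a group of 7 heavy atoms where in the first pair it is meta to a group of 8 heavy atoms, so this is the same kind of change rather than the same change.

Within the data shown here, because the only measured instance gave a 1.4-fold lower number from compound 1 to compound 2 (0.13 log units; within the scatter), the step from compound 3 to compound 4 in this assay is expected to be of similar size, a 1.4-fold lower number from compound 3 to compound 4 (0.14 log units; within the scatter), again within the scatter. Compound 4 is therefore estimated at 32 ug/mL, with a likely range from 18 ug/mL to 60 ug/mL.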

Compound 4, half-maximal inhibitory concentration: 34 ug/mL
The estimate for compound 4 lay 1.1-fold (0.03 log units) below the measured number; the measured number falls inside the stated range.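

In this assay the replacement of methylsulfanyl by aminoamino on the core of compound 3 gives a 1.3-fold lower number from compound 3 to compound 4 (0.11 log units; within the scatter) and so, like the first pair, shows no direction. The two steps agree in size across the two cores: the same change on two cores in this assay, a 1.4-fold lower number (0.13 log units; within the scatter) from compound 1 to compound 2 and a 1.3-fold lower number (0.11 log units; within the scatter) from compound 3 to compound 4, 1.1-fold (0.02 log units) apart, within the scatter of two such steps. This shows that in this assay the change stays within the scatter on both cores, so the small step seen on the core of compound 1 carried over to the core of compound 3; it does not show that aminoamino and methylsulfanyl truly differ on either core, and two steps this small say nothing about how the change would behave on a third core or in another read-out.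

The compounds shown leave open whether any other group in this place, such as a plain amine, dimethylamino, morpholine or a longer chain like butylsulfanyl, would give a step beyond the scatter on either core. They also leave open whether replacing the cyano group with a carboxylic acid or an amide would alter the picture, and whether the same agreement between cores would then still hold.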